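The source may hold more compounds than are shown below. What is called first, only, known or untested is meant among the compounds shown, and "the series" means these compounds.

Measured in an assay on CHO-K1 cells for antagonist activity at adenosine receptor A1 (Homo sapiens), read by a beta-galactosidase reporter, with stated times of 15 min and 6 h; a lower number here means a stronger inhibitor, a higher number a weaker inhibitor:
- compound 1, `Nc1nc(-c2ccco2)nc2sc(CN3CCC(F)CC3)cc12`: 740 nM
- compound 2, `Nc1nc(-c2cc3ccccc3o2)nc2sc(CN3CCC(F)CC3)cc12`: 630 nM
- compound 3, `N#Cc1ccccc1-c1nc(N)c2cc(CN3CCC(F)CC3)sc2n1`: 5050 nM

Compound 3 carries the highest of the three numbers. Moving from the furan-2-yl of compound 1 to the 1-benzofuran-2-yl of compound 2 gives a 1.2-fold lower number from compound 1 to compound 2 (0.07 log units; within the scatter), whereas the 2-cyanophenyl of compound 3 gives a 6.8-fold higher number from compound 1 to compound 3 (0.83 log units; beyond the scatter) and an 8.0-fold higher number from compound 2 to compound 3 (0.90 log units; beyond the scatter).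

Compound 4, `N#Cc1ccc(-c2nc(N)c3cc(CN4CCC(F)CC4)sc3n2)cc1`, is not yet measured. The change from compound 3 is 4-cyanophenyl in place of 2-cyanophenyl on an aromatic carbon. Among the compounds with values here, no measured pair in this set moves a nitrile around the same ring, so none of the three steps bears directly on it; the steps to compound 3 only show that a cyanophenyl in this position has so far given weaker binding than the furan-type groups. Without a comparable step, the expectation for compound 4 is a number close to that of compound 3, with a wide range in either direction, which is an estimated 1.3-fold lower number from compound 3 to compound 4 (0.10 log units; within the scatter). Compound 4 is therefore expected to give about 4000 nM in this assay, estimated within 1000 nM to 16000 nM.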

Compound 4, inhibition constant: 8430 nM
For compound 4 the middle estimate is 2.1-fold (0.32 log units) below the measured one; low and high end bracket the measured number.
By their numbers in this assay, from the lowest: compounds 2 and 1 (each within the scatter of the next); then compounds 3 and 4 (each within the scatter of the next).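

Compound 3 and compound 4 cannot be told apart in this assay, since 4-cyanophenyl in place of 2-cyanophenyl gives a 1.7-fold higher number from compound 3 to compound 4 (0.22 log units; within the scatter) and the two placements of the nitrile on this phenyl ring do not separate them. The weaker binding of compound 3 is therefore not confined to 2-cyanophenyl: 4-cyanophenyl also stands well away from the furan-type groups, with an 11-fold higher number from compound 1 to compound 4 (1.06 log units; beyond the scatter) and a 13-fold higher number from compound 2 to compound 4 (1.13 log units; beyond the scatter) as large steps. No measurement at hand explains why the cyanophenyl groups differ from the furan-type groups.

Still open, as far as these compounds go, is how an unsubstituted phenyl, or a phenyl carrying an amine or a carboxylic acid in place of the nitrile, would compare at this position. All four compounds share the rest of the structure, so whether these steps hold with a morpholine on the side chain is also unknown.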